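The source may report more compounds than this note shows. Statements on the series, on what has been measured and on what is new or still open speak of the compounds shown alone.

Working notes on the series. In an in vitro functional assay on cells for antagonist activity at transient receptor potential cation channel subfamily V member 1 (Homo sapiens), read by FLIPR and calcium flux (a lower number here means a stronger inhibitor, a higher number a weaker inhibitor), compound 3 `COc1ccc(-c2cnc(Nc3cccc4c3CC(O)CC4)o2)cc1` gives 81 nM. Among the three compounds measured it stands second highest; compound 2 `Cc1ccc(-c2cnc(Nc3cccc4c3CC(O)CC4)o2)cc1` gives 62 nM, so a 1.3-fold higher number from compound 2 to compound 3 (0.12 log units; within the scatter), and compound 1 `Cc1ccccc1-c1cnc(Nc2cccc3c2CC(O)CC3)o1` gives 416 nM, so a 5.1-fold lower number from compound 1 to compound 3 (0.71 log units; beyond the scatter). The remaining step, a 6.7-fold lower number from compound 1 to compound 2 (0.83 log units; beyond the scatter), is of similar size.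

Compound 4 `OC1CCc2cccc(Nc3ncc(Cc4ccccc4)o3)c2C1` carries benzyl in place of 4-methoxyphenyl on an aromatic carbon. Going by the values given here, none of the measured steps tests this change: they vary only the groups on the aryl ring, which direct attachment is kept throughout. They do show the assay responding modestly to what sits on that ring, so a change as large as this one is expected to move the number, most likely to a weaker inhibitor.

For compound 4 the expected value in this assay is 350 nM (range 80 nM to 1500 nM), that is a 4.3-fold higher number from compound 3 to compound 4 (0.64 log units; beyond the scatter).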

Compound 4, half-maximal inhibitory concentration: 1820 nM
Compound 4: the middle estimate sits 5.2-fold (0.72 log units) below what was measured, outside the stated range (above it).
By their numbers in this assay, from the lowest: compounds 2 and 3 (each within the scatter of the next); then compound 1; then compound 4.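

At this aromatic carbon next to the ring oxygen, benzyl weakens inhibition far more than any change among the directly attached aryl groups did, with large steps from both the 4-methoxyphenyl and the 4-methylphenyl compounds (a 22-fold higher number from compound 3 to compound 4 (1.35 log units; beyond the scatter)) and (a 29-fold higher number from compound 2 to compound 4 (1.47 log units; beyond the scatter)). Even 2-methylphenyl, the weakest of the directly attached groups, gives a stronger inhibitor than benzyl (a 4.4-fold higher number from compound 1 to compound 4 (0.64 log units; beyond the scatter)). Nothing available explains the size of this loss. From the compounds shown here alone, whether a longer chain such as 2-phenylethyl would lose as much remains open. So does whether methoxy or an amine on the benzyl ring would recover any of it.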